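Phenyl in Place of Methyl: What to Expect for Compound 4

The source may report more compounds than this note shows. Statements on the series, on what has been measured and on what is new or still open speak of the compounds shown alone.

The measured compounds in a functional assay on the whole organism (blood, strain Wistar-Okamoto) with Rattus norvegicus as the target, with a stated time of 5 days; a lower number here means that less compound is needed, a higher number that more compound is needed for the effect:
compound 1 `C/N=C(\NC#N)Nc1cccnc1` gives > 50 mg/kg, which is a limit of the assay and not a number.
compound 2 `CCCCC/N=C(\NC#N)Nc1cccnc1` gives 20 mg/kg.
compound 3 `CC1(/N=C(\NC#N)Nc2cccnc2)CCC1` gives 50 mg/kg.

Compound 1 stands only at a limit, so its position on the numbers is open; it sits at the limit of > 50 mg/kg in this assay, at which 1 of the 3 values shown sits. The account follows the step to compound 4 `N#CN/C(=N\c1ccccc1)Nc1cccnc1`, in which the change is phenyl in place of methyl on a double-bonded nitrogen. Within the data shown here, two measured steps bear on it, both replacing the methyl of compound 1 with something larger: an at least 2.5-fold lower number from compound 1 to compound 2 (0.39 log units; beyond the scatter), and a number no higher from compound 1 to compound 3 (the limit leaves the size open). Between those two larger groups the step is a 2.5-fold higher number from compound 2 to compound 3 (0.40 log units; beyond the scatter). Every enlargement of the methyl so far has given a number no higher than that of compound 1, and one gave a clearly lower one, so a modestly lower number is expected for compound 4, at about an at least 1.6-fold lower number from compound 1 to compound 4 (0.22 log units; that floor lies within the scatter), though the limit at compound 1 keeps the size uncertain. Compound 4 is therefore estimated at 30 mg/kg, within a range from 10 mg/kg to 100 mg/kg.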

Compound 4, minimum effective dose: 5 mg/kg
Compound 4: middle estimate off by 6.0-fold (0.78 log units), on the high side; measured number below the stated range.
By their numbers in this assay, from the lowest: compound 4; then compound 2; then compound 3.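

Phenyl on this double-bonded nitrogen gives the lowest number of the compounds shown in this assay, with a 10-fold lower number from compound 3 to compound 4 (1.00 log units; beyond the scatter) and a 4.0-fold lower number from compound 2 to compound 4 (0.60 log units; beyond the scatter). A ring alone does not account for this pattern, as compound 3 also carries a ring yet has a higher number than compound 2, so the earlier compounds gave no sign that this position could go well beyond the pentyl of compound 2. The change from methyl gives an at least 10-fold lower number from compound 1 to compound 4 (1.00 log units; beyond the scatter) and this size is only a floor, for compound 1 stands at a limit of the assay and not at a number: the limit of > 50 mg/kg in this assay, at which 1 of the 4 values shown sits.

The compounds shown leave open whether the gain belongs to phenyl itself, as they include no chlorophenyl, benzyl or pyridyl on this nitrogen. Going by these compounds, how a chain longer than pentyl would compare also remains open.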